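Oxadiazole amide replaces cyclopropyl amide on a shared core

This account rests on a few compounds, and the source may have more. Where it says the series, first, only, none or still open, it means among the compounds named here.

Measured so far:
compound 1 `Cc1nc(S(C)(=O)=O)ccc1Oc1ncnc(OC2CCN(C(=O)SC(C)C)CC2)c1F` with 6.8 nM
compound 2 `Cc1nc(S(C)(=O)=O)ccc1Oc1ncnc(OC2CCN(C(=O)C3(C)CC3)CC2)c1F` with 761 nM

In a functional assay on isolated protein for inhibition of Glucose-dependent insulinotropic receptor (Homo sapiens), read by HTRF and cAMP accumulation (a lower number here means that less compound is needed, a higher number that more compound is needed for the effect), compound 2 gives 761 nM, the highest of the two numbers; its nearest neighbour is compound 1 with 6.8 nM. Going by the values given here, the only measured step, a 110-fold higher number from compound 1 to compound 2 (2.05 log units; beyond the scatter), shows that the group on the carbonyl carbon governs the read-out strongly. Compound 3 `Cc1nc(S(C)(=O)=O)ccc1Oc1ncnc(OC2CCN(C(=O)c3noc(C(C)C)n3)CC2)c1F` differs from compound 2 in exactly that place: 5-isopropyl-1,2,4-oxadiazol-3-yl in place of 1-methylcyclopropyl on a carbonyl carbon. The new group carries an isopropyl, as the departing group of compound 1 did, and is an aromatic ring rather than a small ring of carbon only. Because compound 1 gives 6.8 nM with an isopropyl at this position, the step from compound 2 to compound 3 is expected to go towards lower numbers, estimated as a 22-fold lower number from compound 2 to compound 3 (1.34 log units; beyond the scatter). Compound 3 is therefore expected to give about 35 nM, in the range 6 nM to 250 nM.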

Compound 3, half-maximal effective concentration: 21.2 nM
For compound 3 the middle estimate is 1.7-fold (0.22 log units) above the measured one; the range from low to high includes it.
By their numbers in this assay, from the lowest: compound 1; then compound 3; then compound 2.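

In this assay, an aromatic ring on the carbonyl carbon recovers most of the ground lost with 1-methylcyclopropyl (a 36-fold lower number from compound 2 to compound 3 (1.56 log units; beyond the scatter)), so a low number at this position does not depend on isopropylsulfanyl. The replacement does not fully match that group, though the remaining gap is modest and still beyond the scatter (a 3.1-fold higher number from compound 1 to compound 3 (0.49 log units; beyond the scatter)). Nothing given here accounts for either step.

The compounds shown leave open how much of this result belongs to the oxadiazole ring and how much to the isopropyl it carries: a methyl or a tert-butyl in place of that isopropyl would separate the two. Also open, as far as these compounds go, is whether another five-membered aromatic ring on the carbonyl carbon, such as a 1,3,4-oxadiazole or an isoxazole, would close the remaining gap to compound 1.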